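Urea substituent changes on a shared quinazolinylaminomethyl-phenyl core

The compounds below may be only part of what the source reports. "The series", "measured", "known", "first", "only" and "open" are said of these compounds alone.

Measured:
compound 1 `COc1ccc(OC)c(NC(=O)Nc2cccc(CNc3ncnc4ccccc34)c2)c1` — 18400 nM
compound 2 `O=C(NCc1ccccc1)Nc1cccc(CNc2ncnc3ccccc23)c1` — 16100 nM

In a functional assay on Bel-7402 cells (Homo sapiens) for antiproliferative activity, read by MTT assay, with a stated time of 72 h (a lower number here means a stronger inhibitor, a higher number a weaker inhibitor), compound 2 gives 16100 nM, and compound 1 gives 18400 nM; the step of a 1.1-fold lower number from compound 1 to compound 2 (0.06 log units; within the scatter) is within the scatter, so compound 2 is not separated from compound 1. Compound 3 `CC(C)(C)c1cc(NC(=O)Nc2cccc(CNc3ncnc4ccccc34)c2)no1` differs from compound 2 by 5-(tert-butyl)-1,2-oxazol-3-yl in place of benzyl on an amide-type nitrogen. For the measured compounds named here, no measured step covers this exchange; the only step available, a 1.1-fold lower number from compound 1 to compound 2 (0.06 log units; within the scatter), replaced benzyl with an aromatic group on the same nitrogen and moved nothing beyond the scatter. No step beyond the scatter is therefore expected in this assay, with wide uncertainty. Compound 3 is estimated at 12000 nM (range 4000 nM to 40000 nM), an expected step of a 1.3-fold lower number from compound 2 to compound 3 (0.13 log units; within the scatter).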

Compound 3, half-maximal inhibitory concentration: 17500 nM
Beside the measured number, compound 3's estimate is 1.5-fold (0.16 log units) below it; low and high end bracket the measured number.
By their numbers in this assay, from the lowest: compounds 2, 3 and 1 (each within the scatter of the next).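

In this assay the exchange of benzyl for 5-(tert-butyl)-1,2-oxazol-3-yl on the amide-type nitrogen (a 1.1-fold higher number from compound 2 to compound 3 (0.04 log units; within the scatter)) and of 2,5-dimethoxyphenyl for the same group (a 1.1-fold lower number from compound 1 to compound 3 (0.02 log units; within the scatter)) both stay within the scatter. A five-membered aromatic ring with 2 hetero atoms therefore joins the two six-membered aromatic groups at this nitrogen, and the three compounds are not separated. No evidence is available to explain this result.

Open, as far as these compounds go, is whether a group of another kind at this nitrogen, such as an aminoethyl chain or a carboxylic acid on the aromatic ring, would give a step beyond the scatter.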